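Capping the Phenol: Expected Cytotoxicity of Compound 4

The compounds below may be only part of what the source reports. "The series", "measured", "known", "first", "only" and "open" are said of these compounds alone.

Compound 1 `COc1cc(CNC(=O)/C=C/c2cccc(O)c2)ccc1OCc1nc(C)c(C)nc1C`: 3680 nM
Compound 2 `COc1cc(CNC(=O)/C=C/c2cccc(OCc3nc(C)c(C)nc3C)c2)ccc1OCc1nc(C)c(C)nc1C`: 8700 nM
Compound 3 `COc1cc(CNC(=O)/C=C/c2ccc(OC)c(OCc3nc(C)c(C)nc3C)c2)ccc1O`: 9250 nM

In a functional assay on SH-SY5Y cells (Homo sapiens) for cytotoxicity, read by MTT assay, with stated times of 24 h and 4 h (a higher number here means that more compound is needed for the effect, a lower number that less compound is needed), compound 1 stands at the lowest of the three numbers, with compound 2 nearest and compound 3 furthest, both beyond the scatter. Compound 4 `COc1cc(OC)c(OC)cc1/C=C/C(=O)NCc1ccc(OCc2nc(C)c(C)nc2C)c(OC)c1` differs from compound 1 by 2,4,5-trimethoxyphenyl in place of 3-hydroxyphenyl on a double-bonded chain carbon bound to a double-bonded chain carbon. Going by the values given here, the one measured single-point step, a 2.4-fold higher number from compound 1 to compound 2 (0.37 log units; beyond the scatter), likewise removes the free hydroxyl donor from that ring and raises the number modestly. Compound 3 also carries no free hydroxyl on the cinnamoyl ring and gives 9250 nM. The change to compound 4 is larger than either, so a modest rise seems the more likely direction. Compound 4 is therefore estimated at 7000 nM, with a range from 3000 nM to 16000 nM. This estimate means an expected 1.9-fold higher number from compound 1 to compound 4 (0.28 log units; within the scatter).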

Compound 4, half-maximal effective concentration: 3620 nM
Compound 4: middle estimate off by 1.9-fold (0.29 log units), on the high side; measured number inside the range.
By their numbers in this assay, from the lowest: compounds 4 and 1 (each within the scatter of the next); then compounds 2 and 3 (each within the scatter of the next).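

In this assay, replacing 3-hydroxyphenyl with 2,4,5-trimethoxyphenyl on this double-bonded chain carbon gives a 1.0-fold lower number from compound 1 to compound 4 (0.01 log units; within the scatter). Unlike compound 2, compound 4 shows that this ring can lose its free hydroxyl while the number stays within the scatter of compound 1, even with a larger group and no hydrogen-bond donor. Nothing available explains why the two groups read alike.

Going by these compounds, it remains open whether all three methoxy groups are needed for this result. On these data alone, how an amine or a carboxylic acid on this ring would read also remains unknown.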